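Removing the methoxy from compound 2

The compounds below may be only part of what the source reports. "The series", "measured", "known", "first", "only" and "open" are said of these compounds alone.

Series notes. In a functional assay on HL-60 cells (Homo sapiens) for cytotoxicity, read by WST assay, with a stated time of 48 h (a lower number here means a stronger inhibitor, a higher number a weaker inhibitor), compound 1 `COc1ccc(/C=C/C[C@@H]2C[C@@H]([C@@H](O)c3ccc(OC)c(OC)c3)CO[C@H]2c2ccc(OC)c(OC)c2)cc1OC` gives 26000 nM, and compound 2 `COc1ccccc1/C=C/C[C@H]1C[C@@H]([C@@H](O)c2ccccc2)CO[C@@H]1c1ccccc1` gives 10100 nM. Among the compounds with values here, for compound 3 `COc1ccc(/C=C/C[C@@H]2C[C@H]([C@H](O)c3ccc(OC)c(OC)c3)CO[C@H]2c2ccc(OC)c(OC)c2)cc1OC` the result in this assay is "not determined" (no result reported); the only difference between compound 1 and compound 3 is the fact that compounds 1 and 3 differ only in the configuration as drawn, so nothing can yet be drawn from that pair. Among the two numbers so far, compound 2 stands lowest, and compound 1 lies a step beyond the scatter above it. Within the data shown here, no pair of measured compounds differs in a single place, so no measured step guides the next change.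

Compound 4 `O[C@@H](c1ccccc1)[C@H]1CO[C@H](c2ccccc2)[C@@H](C/C=C/c2ccccc2)C1` is the next entry for this assay. It differs from compound 2 in one place: hydrogen in place of methoxy on an aromatic carbon. With no measured step of this kind in hand, the expectation for this assay is a step that stays within the scatter or, at most, a modest weakening. Compound 4 is therefore estimated at 15000 nM in this assay, with a range from 5000 nM to 45000 nM. The step this estimate means, a 1.5-fold higher number from compound 2 to compound 4 (0.17 log units; within the scatter), is expected to be small.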

Compound 4, half-maximal inhibitory concentration: 7040 nM
Beside the measured number, compound 4's estimate is 2.1-fold (0.33 log units) above it; measured number inside the range.
By their numbers in this assay, from the lowest: compounds 4 and 2 (each within the scatter of the next); then compound 1.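

In this assay, the series now has its first step in a single place: hydrogen in place of methoxy on an aromatic carbon, ortho to a large group, reading 2-methoxyphenyl to phenyl, gives a 1.4-fold lower number from compound 2 to compound 4 (0.16 log units; within the scatter). The methoxy at this position is therefore not required to hold the number in this assay, and the plain phenyl serves equally well as the reference for further changes here. Within the data shown here, nothing measured so far bears on why this step is so small.

Still open, going by these compounds, is whether a hydroxyl, an amine or a longer chain such as ethoxy at this position would move the number beyond the scatter. This single step also says nothing about the methoxy groups at other positions in compound 1.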